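A few compounds are considered here, and "the series" means these few. Any claim that something is new, unique, unknown or untested is made for them only; others in the source may bear on it.

Compound 1 `COc1ncnc2c1c(-c1cc3ccccc3o1)cn2[C@@H]1O[C@H](CO)[C@@H](O)[C@H]1O` and compound 2 `Cc1ncnc2c1c(-c1cc3ccccc3o1)cn2[C@@H]1O[C@H](CO)[C@@H](O)[C@H]1O` share one core and differ in a single group. In a functional assay on CCRF-CEM cells (Homo sapiens), read by MTT assay, with a stated time of 72 h (on this read-out lower numbers stand for stronger inhibition and higher numbers for weaker inhibition), compound 1 gives 5370 nM, while compound 2 gives 17300 nM, the highest of the two numbers. Methyl in place of methoxy on an aromatic carbon thus makes a 3.2-fold higher number from compound 1 to compound 2 (0.51 log units; beyond the scatter), a modest step beyond the scatter. Compound 3 `Cc1ncnc2c1c(I)cn2[C@@H]1O[C@H](CO)[C@@H](O)[C@H]1O` keeps the methyl of compound 2 but changes another place, on an aromatic carbon of the five-membered aromatic ring: iodo in place of 1-benzofuran-2-yl on an aromatic carbon. Among the measured compounds shown here, the only measured step lies elsewhere, so no measured step gauges the loss of 1-benzofuran-2-yl, and its size can only be a loose guide. Since compound 2 sits at 17300 nM, a lower number is expected in this assay, with wide uncertainty. The expected change is an 8.7-fold lower number from compound 2 to compound 3 (0.94 log units; beyond the scatter). For compound 3 the estimated value is 2000 nM, within an expected range from 150 nM to 20000 nM.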

Compound 3, half-maximal inhibitory concentration: 5480 nM
Compound 3: the middle estimate sits 2.7-fold (0.44 log units) below what was measured; low and high end bracket the measured number.
By their numbers in this assay, from the lowest: compounds 1 and 3 (each within the scatter of the next); then compound 2.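

In this assay the place on the five-membered aromatic ring gets its first measured change, with a modest step of a 3.2-fold lower number from compound 2 to compound 3 (0.50 log units; beyond the scatter) as iodo replaces 1-benzofuran-2-yl. With the methyl held constant, the two aromatic rings of 1-benzofuran-2-yl are therefore not needed to reach the lower number, since a single iodine atom stands in for nine heavy atoms and the number still falls beyond the scatter. Nothing measured here explains this step.

On these data alone, whether an amine or a bromo group at this place would fall nearer compound 3 or compound 2 remains open. Also open, as far as these compounds go, is whether iodo in place of 1-benzofuran-2-yl would give a step of similar size with the methoxy of compound 1 instead of the methyl.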